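Swapping 3-nitrophenyl for 2-bromophenyl in a cell toxicity test

This account rests on a few compounds, and the source may have more. Where it says the series, first, only, none or still open, it means among the compounds named here.

Measured so far in an ADME assay on MT4 cells (Homo sapiens) for cytotoxicity, read by MTT assay, with a stated time of 4 days; on this read-out higher numbers stand for lower toxicity in this test and lower numbers for higher toxicity in this test:
compound 1 `O=C(COc1cccc2ccccc12)N/N=C/c1ccc(O)cc1` gives 26.5 ug/mL
compound 2 `C/C(=N\NC(=O)COc1cccc2ccccc12)c1cccc([N+](=O)[O-])c1` gives 12.1 ug/mL
compound 3 `O=C(COc1cccc2ccccc12)N/N=C/C=C/c1ccccc1` gives 82.7 ug/mL

Compound 2 sits at the low end of this small set, and so is the most toxic to the cells of the three. Compound 1 and compound 3 both lie higher, by margins beyond the usual scatter of the test.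

The next compound, compound 4 `C/C(=N\NC(=O)COc1cccc2ccccc12)c1ccccc1Br`, keeps the rest of compound 2 and changes one group: 2-bromophenyl in place of 3-nitrophenyl on a carbon with a double bond to nitrogen. In words, 2-bromophenyl stands in place of 3-nitrophenyl on a carbon with a double bond to nitrogen.

Among the compounds with values here, only one measured step bears on this place: a 3.1-fold higher number from compound 1 to compound 3 (0.49 log units; beyond the scatter), with 2-phenylethenyl in place of 4-hydroxyphenyl. That modest step shows the number can move when this group changes, but it involves neither group at stake here, so it offers a size and no firm direction. Compound 2 at 12.1 ug/mL already has the lowest number of the three, so a small rise in this assay seems the likelier outcome, smaller than that step and not clearly beyond the scatter. The expected change is a 1.7-fold higher number from compound 2 to compound 4 (0.22 log units; within the scatter) as an estimate only. For compound 4 the estimated value is 20 ug/mL with an expected range from 7 ug/mL to 55 ug/mL in this test.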

Compound 4, half-maximal cytotoxic concentration: 79.8 ug/mL
Compound 4: the middle estimate sits 4.0-fold (0.60 log units) below what was measured, and the stated range ends below it.
By their numbers in this assay, from the lowest: compound 2; then compound 1; then compounds 4 and 3 (each within the scatter of the next).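

Changing only 3-nitrophenyl to 2-bromophenyl on a carbon with a double bond to nitrogen gives, in this assay, a 6.6-fold higher number from compound 2 to compound 4 (0.82 log units; beyond the scatter), which means lower toxicity in this test while the rest of the molecule stays the same. Within the data shown here, the only earlier step at this place, a 3.1-fold higher number from compound 1 to compound 3 (0.49 log units; beyond the scatter), involved neither of these groups, so this new step is the first to show that two substituted phenyl groups on this carbon can give clearly different numbers. No measurement shown here gives a reason for the rise.

The swap takes away a nitro group and brings in a bromine, and the two also sit at different places on the phenyl ring, so these compounds leave open whether losing the nitro group, gaining the bromine or the change of place on the ring accounts for the step. Also open, as far as these compounds go, is how a plain phenyl group on the same carbon would compare, or a phenyl ring carrying an amine or a carboxylic acid, any of which could help separate these possibilities.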